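Replacing the aryl group on the thiazole core of compound 3

The source may hold more compounds than are shown below. What is called first, only, known or untested is meant among the compounds shown, and "the series" means these compounds.

Measured compounds:
compound 1 `O=C(O)Cc1sc(CS(=O)(=O)c2ccc(Cl)cc2)nc1-c1ccc(Cl)cc1`: 730 nM
compound 2 `O=C(O)Cc1sc(C(c2ccc(F)cc2)c2ccc(F)cc2)nc1-c1cccc(F)c1`: 18 nM
compound 3 `N#Cc1cc(-c2nc(C(c3ccc(F)cc3)c3ccc(F)cc3)sc2CC(=O)O)ccc1F`: 520 nM

All three were tested in an in vitro functional assay on HEK285-7 cells for antagonist activity at prostaglandin D2 receptor 2 (Homo sapiens), read by BRET and beta-arrestin recruitment; on this read-out lower numbers stand for stronger inhibition and higher numbers for weaker inhibition. Compound 3 gives 520 nM, the second highest of the three numbers; compound 1 gives 730 nM, within the scatter of compound 3, while compound 2 gives 18 nM, far lower. Compound 4 `O=C(O)Cc1sc(C(c2ccc(F)cc2)c2ccc(F)cc2)nc1-c1ccnc(Cl)c1` has not yet been measured. It differs from compound 3 in one place: 2-chloropyridin-4-yl in place of 3-cyano-4-fluorophenyl on an aromatic carbon.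

Among the compounds with values here, only one measured step touches the same position, a 29-fold higher number from compound 2 to compound 3 (1.46 log units; beyond the scatter). That step shows the group on this carbon can move the number by a large amount, but it involved a different pair of groups, so it gives no direction for the new one. Since compound 2, carrying 3-fluorophenyl, sits far below compound 3, the number for compound 4 is estimated to fall between those two, a moderate step downward, a 4.3-fold lower number from compound 3 to compound 4 (0.64 log units; beyond the scatter). Compound 4 is therefore expected to give about 120 nM, with a range from 25 nM to 600 nM.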

Compound 4, half-maximal inhibitory concentration: 39 nM
Estimate against measurement, compound 4: 3.1-fold (0.49 log units) above, and the stated range covers the measured number.
By their numbers in this assay, from the lowest: compound 2; then compound 4; then compounds 3 and 1 (each within the scatter of the next).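

Putting 2-chloropyridin-4-yl in place of 3-cyano-4-fluorophenyl in this assay gives a 13-fold lower number from compound 3 to compound 4 (1.12 log units; beyond the scatter), so a change on this carbon can also bring a large drop in the number, and an aromatic ring with a hetero atom can sit here with a low number. Putting the same group in place of 3-fluorophenyl gives a 2.2-fold higher number from compound 2 to compound 4 (0.34 log units; beyond the scatter), a modest step that is still beyond the scatter, so 3-fluorophenyl remains the group with the lowest number at this position among those shown. Nothing available explains why these groups differ.

Going by these compounds, the ring nitrogen and the chlorine enter together, so their separate contributions remain unknown. A plain pyridin-4-yl group would help separate them, and a 2-aminopyridin-4-yl group would show what happens when an amine replaces the chlorine.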